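This account rests on a few compounds, and the source may have more. Where it says the series, first, only, none or still open, it means among the compounds named here.

Measured so far:
compound 1, `Oc1nc2nonc2nc1Nc1ccccc1`, 66700 nM
compound 2, `CC(C)(C)c1cccc(Nc2nc3nonc3nc2O)c1`, 2200 nM

Both compounds were tested in an assay on mitochondria from L6 cells (Rattus norvegicus) for activation, with a stated time of 90 min; on this read-out lower numbers stand for an effect already at smaller amounts and higher numbers for an effect only at larger amounts of compound. Compound 1 stands highest of the two numbers; its nearest neighbour is compound 2, reached by a 30-fold lower number from compound 1 to compound 2 (1.48 log units; beyond the scatter), where tert-butyl in place of hydrogen on an aromatic carbon makes the difference.

The unmeasured compound 3, `CC(=O)c1ccc(Nc2nc3nonc3nc2O)cc1`, differs from compound 1 by acetyl in place of hydrogen on an aromatic carbon. Within the data shown here, the only measured step that bears on this change is the one from compound 1 to compound 2, which was large. It shows that a group entering on the benzene ring of compound 1 can move the number far, but the group there was tert-butyl at another place, not acetyl para to a large group, so it gives only loose guidance. A step downward in this assay is expected for compound 3, but a smaller one than that to compound 2, estimated as a 2.2-fold lower number from compound 1 to compound 3 (0.35 log units; beyond the scatter). Compound 3 is therefore expected to show about 30000 nM, with a range from 6000 nM to 120000 nM.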

Compound 3, half-maximal effective concentration: 93700 nM
Compound 3: middle estimate off by 3.1-fold (0.49 log units), on the low side; low and high end bracket the measured number.
By their numbers in this assay, from the lowest: compound 2; then compounds 1 and 3 (each within the scatter of the next).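

In this assay, acetyl in place of hydrogen on an aromatic carbon, para to a large group, gives a 1.4-fold higher number from compound 1 to compound 3 (0.15 log units; within the scatter), so this change cannot be told apart from repeat-measurement scatter. The earlier step, a 30-fold lower number from compound 1 to compound 2 (1.48 log units; beyond the scatter), showed that a group entering the aromatic ring can matter a great deal, whereas this result shows that a new group there does not always do so. The two groups differ and also sit at different places on the ring, so these two steps cannot separate the effect of the group from that of its place, and nothing available here explains the result.

The compounds shown leave open what tert-butyl would do at the place acetyl holds in compound 3, and what acetyl would do at the place tert-butyl holds in compound 2. They also leave open whether a different group at the acetyl place, such as an amine or a carboxylic acid, would give a step beyond the scatter.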